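A few compounds are considered here, and "the series" means these few. Any claim that something is new, unique, unknown or untested is made for them only; others in the source may bear on it.

Notes on the series, step from compound 1 to compound 4.

Of the compounds shown here, three of the shared core have been measured in a functional assay on MCF7 cells (Homo sapiens) for cytotoxicity, read by MTT assay, with a stated time of 72 h; on this read-out higher numbers stand for weaker inhibition and lower numbers for stronger inhibition. Compound 1 `Cc1ccc(CSc2cc(Cl)c(C)cc2S(=O)(=O)/N=C(\N)n2nc(C)cc2-c2ccccc2)cc1` gives 89000 nM. Compound 2 `Cc1cc(S(=O)(=O)/N=C(\N)n2nccc2-c2ccccc2)c(SCc2cccc(Cl)c2)cc1Cl` gives 88000 nM. Compound 3 `Cc1cccc(CSc2cc(Cl)c(C)cc2S(=O)(=O)/N=C(\N)n2nc(C)cc2-c2ccccc2)c1` gives 105000 nM. Within the data shown here, on these numbers compound 1 stands second highest of the three, with compound 2 nearest and compound 3 furthest, and both of those gaps lie within the scatter; no compound here can be set apart from the others.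

Compound 4 `Cc1cc(-c2ccccc2)n(/C(N)=N/S(=O)(=O)c2cc(C)c(Cl)cc2SCc2ccccc2C)n1` has not yet been measured in this assay. It differs from compound 1 in one place: 2-methylphenyl in place of 4-methylphenyl on a saturated chain carbon bound to a sulfur.

Among the measured compounds shown here, one measured step bears directly on this change: the step from compound 1 to compound 3 in this assay, a 1.2-fold higher number from compound 1 to compound 3 (0.07 log units; within the scatter), which likewise relocates the methyl on the phenyl that sits on the saturated chain carbon bound to a sulfur. For the measured compounds named here, compound 2 has no single-point step to compound 1; its value simply lies within the scatter of compound 1. With that one relevant step flat, no movement beyond the scatter is expected in this assay for compound 4.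

Compound 4 is therefore estimated at 90000 nM, within the range 45000 nM to 180000 nM, which means an expected step of a 1.0-fold higher number from compound 1 to compound 4 (0.00 log units; within the scatter).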

Compound 4, half-maximal inhibitory concentration: 80000 nM
Compound 4: the middle estimate sits 1.1-fold (0.05 log units) above what was measured; the measured number falls inside the stated range.
By their numbers in this assay, from the lowest: compounds 4, 2, 1 and 3 (each within the scatter of the next).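

In this assay the 2-methylphenyl on a saturated chain carbon bound to a sulfur completes a set of three methylphenyl groups at this place, and it reads flat against both of the others (a 1.1-fold lower number from compound 1 to compound 4 (0.05 log units; within the scatter)) (a 1.3-fold lower number from compound 3 to compound 4 (0.12 log units; within the scatter)), with each step within the scatter. Compound 1 and compound 3 alone showed only that the 4-methylphenyl and the 3-methylphenyl could not be told apart; compound 4 extends this to all three, so among compounds 1, 3 and 4 the place of the methyl on this phenyl leaves no mark on the number in this assay. No independent measurement is available to explain why these three compounds read alike.

From the compounds shown here alone, all three groups at this place are methylphenyl groups of the same atoms, so it remains open whether a different group, such as a phenyl carrying an amine or a carboxylic acid, or a longer chain between the sulfur and the phenyl, would move the number in this assay beyond the scatter. Going by these compounds, it also remains open whether the 2-methylphenyl would read the same way on the core of compound 2.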